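Solubility at Low pH Across a Shared Bicyclic Core

The compounds below may be only part of what the source reports. "The series", "measured", "known", "first", "only" and "open" are said of these compounds alone.

Measured compounds:
- compound 1 `CNc1nc(NCCCN(C)C)c2sc(-c3ccc(-n4cccn4)cc3)cc2n1`: 217 ug/mL
- compound 2 `CNc1nc(NCCCN(C)C)c2oc(-c3ccccc3)cc2n1`: 214 ug/mL
- compound 3 `CNc1nc(NCCCN(C)C)c2cc(-c3ccccc3)sc2n1`: 216 ug/mL

In a physicochemical assay for solubility, at pH 2 (a lower number here means a less soluble compound, a higher number a more soluble compound), compound 1 gives 217 ug/mL, the highest of the three numbers, but compound 3 with 216 ug/mL and compound 2 with 214 ug/mL sit within the scatter of it, so no order among them can be claimed. Compound 4 `CNc1nc(NCCCN(C)C)c2sc(-c3ccc(C(F)(F)F)cc3)cc2n1` has not been measured. It differs from compound 1 in one place: trifluoromethyl in place of 1H-pyrazol-1-yl on an aromatic carbon. Within the data shown here, no measured pair shows this change, so its size in this assay is unknown. A modest lowering is expected, since the three measured values lie so close that the shared core seems to set the number. For compound 4 the estimated value is 150 ug/mL, with a range from 60 ug/mL to 230 ug/mL, corresponding to the expected step of a 1.4-fold lower number from compound 1 to compound 4 (0.16 log units; within the scatter).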

Compound 4, solubility: 240 ug/mL
Compound 4: the middle estimate sits 1.6-fold (0.20 log units) below what was measured, and the stated range ends below it.
By their numbers in this assay, from the lowest: compounds 2, 3, 1 and 4 (each within the scatter of the next).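

In this assay, trifluoromethyl in place of 1H-pyrazol-1-yl on this aromatic carbon gives a 1.1-fold higher number from compound 1 to compound 4 (0.04 log units; within the scatter), the first step read at this position, and it lies within the scatter. So at this position, a five-membered aromatic ring with hydrogen-bond acceptors can give way to a group with no ring and no such acceptors without a readable change in this read-out. Nothing available explains this result. Going by these compounds, whether an amine or a carboxylic acid on the same carbon would give a step beyond the scatter remains open.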